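The source may hold more compounds than are shown below. What is called first, only, known or untested is meant among the compounds shown, and "the series" means these compounds.

Measured compounds:
compound 1, `O=C1CCC(N2C(=O)c3ccc(Nc4ccccc4)cc3C2=O)C(=O)N1`: 6%
compound 2, `COc1ccc(Nc2cccc3c2C(=O)N(C2CCC(=O)NC2=O)C3=O)cc1`: 13%

In an assay on FRT-Jurkat cells for inhibition of nuclear factor NF-kappa-B complex (Homo sapiens), read by flow cytometry, with a stated time of 24 h, tested at 10 uM (a higher number here means more inhibition at the concentration tested (going by the name of the read-out), a lower number less inhibition), compound 1 gives 6%, and compound 2 gives 13%. The two numbers lie within the usual scatter of each other, so neither compound can be said to inhibit more than the other; both show only slight inhibition at the concentration tested. Compound 3, `CCCc1ccc(Nc2ccc3c(c2)C(=O)N(C2CCC(=O)NC2=O)C3=O)cc1`, is not yet measured in this assay. It differs from compound 1 in one place: propyl in place of hydrogen on an aromatic carbon. Cut one bond further out, the same difference reads phenyl to 4-propylphenyl. Among the measured compounds shown here, no step between measured compounds is available, so nothing among the measured numbers shows how such a change acts in this assay. With both measured compounds near the bottom of the scale, the expected step of a number 4 percentage points higher from compound 1 to compound 3 (within the scatter) is small and not beyond the scatter, a slight rise being as likely as none. Compound 3 is therefore expected to give about 10% in this assay, with a range from 0% to 25%.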

Compound 3, a percentage reported as inhibition, at one concentration (the size of the read-out at that concentration, not a potency): 10%
Beside the measured number, compound 3's estimate shows no gap at the digits printed, within the range that was stated.
By their numbers in this assay, from the lowest: compounds 1, 3 and 2 (each within the scatter of the next).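

Among the compounds shown here, replacing hydrogen with propyl, which turns phenyl into 4-propylphenyl, gives the first direct step in this assay: a number 4 percentage points higher from compound 1 to compound 3 (within the scatter). This shows that, on this aromatic carbon para to a large group, adding this chain of 3 carbon atoms to the core of compound 1 does not produce a change that can be told from the scatter, and the reading stays near the bottom of the scale. No separate measurement is available to explain the size of this step.

From the compounds shown here alone, it remains open whether a longer chain such as hexyl, an amine or a carboxylic acid at the same position would give a different reading. The compounds shown also do not reveal whether any group at this position can raise inhibition beyond the scatter.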